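The compounds below may be only part of what the source reports. "The series", "measured", "known", "first", "only" and "open" are said of these compounds alone.

Compound 2 `CN(C)CCCCCCOc1ccc2oc(-c3ccccc3)cc(=O)c2c1` — 432 nM
Compound 1 `O=c1cc(-c2ccccc2)oc2cccc(OCCCCN3CCC(O)CC3)c12` — 58 nM

Both measured compounds were tested in an assay on isolated protein (Cavia porcellus) with Sigma non-opioid intracellular receptor 1 (Homo sapiens) as the target, read by radioligand binding; on this read-out lower numbers stand for stronger inhibition and higher numbers for weaker inhibition. Of the two numbers, compound 2 gives the higher one, 432 nM, which stands for weaker inhibition. Among the compounds with values here, the only comparison is compound 1, whose number, 58 nM, is lower by a gap beyond the scatter. The two compounds differ in more than one place, so that gap shows only what the two values are and not what any single change does.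

Compound 3 `CN(C)CCCCCCCCCOc1ccc2oc(-c3ccccc3)cc(=O)c2c1` has not been measured. It differs from compound 2 in one place: 3-(dimethylamino)propyl in place of dimethylamino on a saturated chain carbon, six bonds along the chain from an oxygen on an aromatic ring. Within the data shown here, nothing among the measured compounds isolates a change of this kind, so there is no measured step to lean on. The chain joining the dimethylamino group to the oxygen on the aromatic ring simply grows longer, and a chain of this length appears in neither measured compound. A modest shift in this assay is expected, toward a lower number, with little confidence in its size. For compound 3 the expected step is a 2.2-fold lower number from compound 2 to compound 3 (0.33 log units; beyond the scatter). Compound 3 is therefore estimated at 200 nM, within a range from 50 nM to 800 nM.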

Compound 3, half-maximal inhibitory concentration: 334 nM
Beside the measured number, compound 3's estimate is 1.7-fold (0.22 log units) below it; measured number inside the range.
By their numbers in this assay, from the lowest: compound 1; then compounds 3 and 2 (each within the scatter of the next).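

In this assay, within the data shown here, this is the first comparison that isolates a single change: 3-(dimethylamino)propyl in place of dimethylamino on a saturated chain carbon, six bonds along the chain from an oxygen on an aromatic ring, gives a 1.3-fold lower number from compound 2 to compound 3 (0.11 log units; within the scatter). Compound 2 and compound 3 therefore cannot be told apart in this assay, and at this position the added chain carbons leave no effect that can be distinguished from ordinary repeat-to-repeat variation, at least for this one extension with the dimethylamino end group kept in place. Nothing available explains why the change leaves the reading so little altered.

Only these two chain lengths are compared with a dimethylamino end, so the compounds shown leave open whether a shorter chain, such as 2-(dimethylamino)ethyl, or an intermediate length would behave the same way. They also leave open whether a different amine at the chain end, such as diethylamino, would respond to chain length in the same way, and compound 1 cannot settle either question, as it differs from both in more than one place.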